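Bromo for methoxy at the limit of the assay

The source may hold more compounds than are shown below. What is called first, only, known or untested is meant among the compounds shown, and "the series" means these compounds.

In a functional assay on KB cells (Homo sapiens) for cytotoxicity, read by MTT assay, with a stated time of 72 h (a lower number here means a stronger inhibitor, a higher number a weaker inhibitor), compound 1 (`Cc1ccc(S(=O)(=O)c2nc3ccccc3nc2N2CCCC2)cc1`) gives > 50000 nM as a limit of the assay and not a number. Compound 2 (`COc1ccc(S(=O)(=O)c2nc3ccccc3nc2N2CCCC2)cc1`) gives > 50000 nM which is likewise only a limit. Compound 2 therefore offers no measured potency as a starting point. Compound 3 (`O=S(=O)(c1ccc(Br)cc1)c1nc2ccccc2nc1N1CCCC1`) carries bromo in place of methoxy on an aromatic carbon, para to a large group (bromo in place of methoxy on an aromatic carbon). For the measured compounds named here, the one measured step at this place, methoxy in place of methyl, is a step that the two limits leave unreadable from compound 1 to compound 2 and so no change beyond the usual scatter is expected in this assay in either direction. The data so far show a single feature (the limit of > 50000 nM in this assay, at which 2 of the 2 values shown sit) and give no number from which to scale a change. The expected step is a number no higher from compound 2 to compound 3 (the limit leaves the size open) and this remains only an estimate. Compound 3 is estimated at 50000 nM with an expected range from 20000 nM to 100000 nM. It is expected that compound 3 may well give only a limit.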

Compound 3, half-maximal inhibitory concentration: > 50000 nM
Compound 3: a limit, no number; the forecaster's own chance of this, stated with the estimate: 75%; the middle value lies on the limit itself.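

In this assay compound 3 gives > 50000 nM, again a limit of the assay and not a number. For the compounds shown here, no step among compound 1, compound 2 and compound 3 can therefore be read: the limit of > 50000 nM in this assay, at which 3 of the 3 values shown sit. The compounds shown leave open how strongly any of the three acts in this assay, and whether methyl, methoxy or bromo makes any difference there.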